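From a Diethylamino Chain to a Dibutylamino Chain

A few compounds are considered here, and "the series" means these few. Any claim that something is new, unique, unknown or untested is made for them only; others in the source may bear on it.

Compound 1 `CCC(C)Oc1c(-c2cc(OC)c(OC)c(OC)c2)oc2ccccc2c1=O` gives 38600 nM
Compound 2 `CCN(CC)CCCOc1c(-c2cc(OC)c(OC)c(OC)c2)oc2ccccc2c1=O` gives 13600 nM
Compound 3 `CCN(CC)CCCCOc1c(-c2cc(OC)c(OC)c(OC)c2)oc2ccccc2c1=O` gives 13700 nM

All three values come from a functional assay on PC-3 cells (Homo sapiens) for antiproliferative activity, read by WST assay, with a stated time of 3 days (a higher number here means a weaker inhibitor, a lower number a stronger inhibitor), and are half-maximal inhibitory concentrations. Two steps place compound 3. One is a 1.0-fold higher number from compound 2 to compound 3 (0.00 log units; within the scatter) and the other is a 2.8-fold lower number from compound 1 to compound 3 (0.45 log units; beyond the scatter), so compound 3 shares the low end of this small range with compound 2.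

Compound 4 `CCCCN(CCCC)CCCOc1c(-c2cc(OC)c(OC)c(OC)c2)oc2ccccc2c1=O` keeps the shared core and differs only in the side chain (dibutylamino in place of (diethylamino)methyl on a saturated chain carbon, three bonds along the chain from an oxygen on an aromatic ring), with dibutylamino in place of (diethylamino)methyl on a saturated chain carbon. The nearest evidence is a 1.0-fold higher number from compound 2 to compound 3 (0.00 log units; within the scatter), a change in the same chain. The replacement of sec-butyl gave a 2.8-fold lower number from compound 1 to compound 2 (0.45 log units; beyond the scatter), a modest step. Among the compounds with values here, no measured step changes the groups on the nitrogen, so this expectation is uncertain. In this assay only a small step, within the scatter, is expected, and its estimated size is a 1.2-fold lower number from compound 3 to compound 4 (0.10 log units; within the scatter). Compound 4 is estimated at 11000 nM, within an expected range of 5000 nM to 24000 nM.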

Compound 4, half-maximal inhibitory concentration: 7100 nM
Compound 4: middle estimate off by 1.5-fold (0.19 log units), on the high side; low and high end bracket the measured number.
By their numbers in this assay, from the lowest: compounds 4, 2 and 3 (each within the scatter of the next); then compound 1.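

In this assay, within the data shown here, this result is the first test of the groups on the nitrogen rather than the length of the chain. With dibutylamino in place of diethylamino there is a 1.9-fold lower number from compound 2 to compound 4 (0.28 log units; within the scatter), and the step from the longer chain reads a 1.9-fold lower number from compound 3 to compound 4 (0.29 log units; within the scatter), so neither change can be told from the scatter and this position accepts the butyl groups without a clear difference. The step from the sec-butyl compound, with 3-(dibutylamino)propyl entering, is a 5.4-fold lower number from compound 1 to compound 4 (0.74 log units; beyond the scatter), which is modest but beyond the scatter, so the amine chains seen here still stand apart from sec-butyl.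

From the compounds shown here alone, whether a dimethylamino group or a carboxylic acid in place of dibutylamino would give a step beyond the scatter stays open. Nothing shown gives a reason for these numbers.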